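This account rests on a few compounds, and the source may have more. Where it says the series, first, only, none or still open, it means among the compounds named here.

Two compounds have a number in a functional assay on A549 cells (Homo sapiens) for inhibition, read by MTT assay, with a stated time of 72 h; a higher number here means a weaker inhibitor, a lower number a stronger inhibitor. Compound 1 `CCOc1ccc(C2CC2C(=O)NNC(=O)c2ccncc2)cc1` gives 43000 nM. Compound 2 `CC(C)=CCC/C(C)=C/COc1ccc(C2CC2C(=O)NNc2nncc3ccccc23)cc1` gives 36000 nM; compound 2 holds the lowest of the two numbers, but its nearest neighbour, compound 1, lies within the scatter of it, so the two cannot be ordered. Compound 3 `CC(C)=CCC/C(C)=C/COc1ccc(C2CC2C(=O)NNC(=O)c2ccncc2)cc1` has not been measured in this assay. Against compound 2 the change is a group of 8 heavy atoms (6 carbon, 1 nitrogen, 1 oxygen; one six-membered aromatic ring with 1 hetero atom) in place of a group of 10 heavy atoms (8 carbon, 2 nitrogen; one six-membered aromatic ring of carbon only, one six-membered aromatic ring with 2 hetero atoms), on an amine nitrogen; the group that enters is the one compound 1 also carries, while the chain on the oxygen is kept from compound 2. Among the measured compounds shown here, no step between measured compounds is known, and the two measured values sit within the scatter of each other, so the expected change is a 1.1-fold higher number from compound 2 to compound 3 (0.05 log units; within the scatter), in neither direction beyond the scatter. Compound 3 is therefore expected to give 40000 nM, with a range of 15000 nM to 110000 nM.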

Compound 3, half-maximal inhibitory concentration: 78000 nM
Compound 3: middle estimate off by 2.0-fold (0.29 log units), on the low side; measured number inside the range.
By their numbers in this assay, from the lowest: compounds 2, 1 and 3 (each within the scatter of the next, the first and the last beyond it).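

In this assay the group on the amine nitrogen now has a readable step: with the chain on the oxygen kept, (pyridin-4-yl)carbonyl entering gives a 2.2-fold higher number from compound 2 to compound 3 (0.34 log units; beyond the scatter) and this modest step is the only one here beyond the scatter. Among the compounds shown here, the other change, 2,6-dimethylhepta-1,5-dien-1-yl in place of methyl on a saturated chain carbon bound to an oxygen on an aromatic ring, gives a 1.8-fold higher number from compound 1 to compound 3 (0.26 log units; within the scatter) and so sets no order for that pair. No measurement at hand bears on the reason for the step at the amine nitrogen.

As far as these compounds go, it remains open whether the same exchange on the amine nitrogen gives a similar step when the chain of compound 1 is kept on the oxygen. From the compounds shown here alone, how a benzoyl or an acetyl group would compare on that nitrogen also remains open.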